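Methyl for fluoro on the aromatic ring of compound 1

The compounds below may be only part of what the source reports. "The series", "measured", "known", "first", "only" and "open" are said of these compounds alone.

Measured so far in a functional assay on the whole organism (strain albino Sprague-Dawley) with Rattus norvegicus as the target, in the maximal electroshock model; on this read-out lower numbers stand for an effect already at smaller amounts and higher numbers for an effect only at larger amounts of compound:
- compound 1, `CC(C)[C@@H](N)C(=O)NCc1ccc(F)cc1`: compound 1 gives 21 mg/kg.
- compound 2, `CC(C)(C)[C@@H](N)C(=O)NCc1ccc(OCc2cccc(F)c2)cc1`: compound 2 reaches only a limit of the assay, > 30 mg/kg.
- compound 3, `COC[C@@H](N)C(=O)NCc1ccc(OCc2cccc(F)c2)cc1`: compound 3 gives 13 mg/kg.

All three compounds share an amide core carrying an amino acid side chain. Among the two numbers given, compound 1 stands highest, with compound 3 as its nearest neighbour within the scatter. The value of compound 2 is a limit and not a number; (the limit of > 30 mg/kg in this assay, at which 1 of the 3 values shown sits).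

Among the compounds with values here, the only step between compounds that differ in one place is an at least 2.3-fold lower number from compound 2 to compound 3 (0.36 log units; beyond the scatter), where methoxymethyl replaces tert-butyl on a saturated chain carbon bound to an amine nitrogen and a carbonyl carbon.

Compound 4, `Cc1ccc(CNC(=O)[C@H](N)C(C)C)cc1`, differs from compound 1 in another place: methyl in place of fluoro on an aromatic carbon. Within the data shown here, no measured step touches this position, so the step from compound 2 to compound 3 offers no direct guide, and no shift beyond the scatter is expected in this assay.

Compound 4 is therefore estimated at 24 mg/kg, with a range from 10 mg/kg to 60 mg/kg. This estimate means an expected step of a 1.1-fold higher number from compound 1 to compound 4 (0.06 log units; within the scatter), staying within the scatter.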

Compound 4, dose for half-maximal effect: 50 mg/kg
The estimate for compound 4 lay 2.1-fold (0.32 log units) below the measured number; the range from low to high includes it.
By their numbers in this assay, from the lowest: compounds 3 and 1 (each within the scatter of the next); then compound 4.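

In this assay, methyl in place of fluoro on an aromatic carbon gives a 2.4-fold higher number from compound 1 to compound 4 (0.38 log units; beyond the scatter), so this place on the ring affects the dose needed, which the earlier step on the saturated chain carbon could not show. The change looks small when counted: each group has 1 heavy atom, no ring, 0 hydrogen-bond donors, 0 hydrogen-bond acceptors and no net charge, so these counts alone do not predict the shift between compound 1 and compound 4. Nothing in the data shown explains why the two groups differ at this place.

From the compounds shown here alone, whether other groups at this place, such as chloro, methoxy or trifluoromethyl, would stay close to fluoro or move towards methyl remains open. Going by these compounds, it is also open whether methyl and fluoro would differ in the same way on another side chain, such as the methoxymethyl of compound 3, since this pair shares a single side chain and has no group larger than fluoro or methyl on the ring.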